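A Chloro for Fluoro Swap at the Assay Limit

The source may hold more compounds than are shown below. What is called first, only, known or untested is meant among the compounds shown, and "the series" means these compounds.

In a functional assay on U-87MG ATCC cells for cytotoxicity against U-87 MG (Homo sapiens), read by MTT assay, with a stated time of 72 h (on this read-out lower numbers stand for stronger inhibition and higher numbers for weaker inhibition), compound 1 `COc1ccc2nc(NC(=O)c3cn(-c4ccccc4)nc3-c3ccc(F)cc3)sc2c1` gives > 50000 nM, which is a limit and not a number. Compound 2 `Cc1ccc2nc(NC(=O)c3cn(-c4ccccc4)nc3-c3ccc(F)cc3)sc2c1` gives > 50000 nM, also a limit. Within the data shown here, the only measured step is a step that the two limits leave unreadable from compound 1 to compound 2, so the sole guide is the limit of > 50000 nM in this assay, at which 2 of the 2 values shown sit. Compound 3 `COc1ccc2nc(NC(=O)c3cn(-c4ccccc4)nc3-c3ccc(Cl)cc3)sc2c1` differs from compound 1 by one change, (chloro in place of fluoro on an aromatic carbon), which reads 4-fluorophenyl to 4-chlorophenyl. Among the measured compounds shown here, no measured step gives a size to carry over, so no shift beyond the scatter is expected in this assay. The expected step is a number no higher from compound 1 to compound 3 (the limit leaves the size open). Compound 3 is estimated at 50000 nM, with an expected range of 20000 nM to 100000 nM.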

Compound 3, half-maximal inhibitory concentration: 21200 nM
The estimate for compound 3 lay 2.4-fold (0.37 log units) above the measured number; the range from low to high includes it.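

In this assay, the change from 4-fluorophenyl to 4-chlorophenyl gives an at least 2.3-fold lower number from compound 1 to compound 3 (0.37 log units; beyond the scatter), so this position on the six-membered aromatic ring responds to the exchange of one halogen for another. Going by these compounds, the true size of the step stays open, as the value of compound 1 is a limit. Compound 3 is the only compound shown with a number rather than a limit: the limit of > 50000 nM in this assay, at which 2 of the 3 values shown sit.

On these data alone, whether bromo or trifluoromethyl at this position would carry the trend further remains open. So does whether chloro would give a similar step in compound 2.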